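This account rests on a few compounds, and the source may have more. Where it says the series, first, only, none or still open, it means among the compounds named here.

Working notes on the series. The three compounds measured so far share one core, shown for compound 1 as `O=C(Nc1cccc(-n2cc(-c3ccncc3)c(-c3cc(O)cc(Cl)c3)n2)c1)Nc1ccc(Cl)c(C(F)(F)F)c1`; compound 2 is `COc1cc(Cl)cc(-c2nn(-c3cccc(NC(=O)Nc4ccc(Cl)c(C(F)(F)F)c4)c3)cc2-c2ccncc2)c1` and compound 3 is `COc1cc(Cl)cc(-c2nn(-c3cccc(NC(=O)Nc4cc(C(F)(F)F)cc(C(F)(F)F)c4)c3)cc2-c2ccncc2)c1`. In a functional assay on UACC-62 cells (Homo sapiens) for inhibition, read by sulforhodamine B assay, with a stated time of 48 h, tested at 10 uM (a lower number here means a stronger effect, a higher number a weaker effect of the compound at the concentration tested), compound 1 gives -1.44%, compound 2 gives 6.62% and compound 3 gives -21.2%. On these numbers compound 3 stands lowest of the three, its nearest neighbour being compound 1 and its furthest compound 2, both gaps beyond the scatter. Within the data shown here, the only single-place step measured is a number 8.1 percentage points higher from compound 1 to compound 2 (within the scatter), so the one change tried so far on the methoxy side left the read-out within the scatter. Compound 2 and compound 3 differ at the urea aryl group in more than one place, so their two values show only that the bis-trifluoromethyl pattern sits lower.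

Compound 4, `COc1cc(Cl)cc(-c2nn(-c3cccc(NC(=O)Nc4cccc(C(F)(F)F)c4)c3)cc2-c2ccncc2)c1`, differs from compound 3 by hydrogen in place of trifluoromethyl on an aromatic carbon. Among the measured compounds shown here, no measured step touches the aryl urea, so nothing in hand says how large a step to expect in this assay or in which direction. Given that compound 3 sits at -21.2% and the other two members lie higher, the expected step for compound 4 is a number 13.2 percentage points higher from compound 3 to compound 4 (beyond the scatter), a modest rise that stays close to the scatter. Compound 4 is therefore estimated at -8%, with a range from -35% to 20%.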

Compound 4, a percentage reported as activity, at one concentration (the size of the read-out at that concentration, not a potency): -11.5%
The estimate for compound 4 lay 3.5 percentage points above the measured number; the measured number falls inside the stated range.
By their numbers in this assay, from the lowest: compounds 3 and 4 (each within the scatter of the next); then compounds 1 and 2 (each within the scatter of the next).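

In this assay, hydrogen in place of trifluoromethyl on an aromatic carbon of the urea aryl group gives a number 9.7 percentage points higher from compound 3 to compound 4 (within the scatter), so this single change on that group stays inside the usual variation of the read-out. Hydrogen in place of chloro on the same aryl group gives a number 18.1 percentage points lower from compound 2 to compound 4 (beyond the scatter), which is the first single-place step on this group to pass beyond the scatter and shows that the read-out can respond to a change here, a response that the hydrogen-for-trifluoromethyl step does not show. Nothing measured on these compounds accounts for the difference between the two steps.

The compounds shown leave open how an amine or a carboxylic acid on this aryl group would move the read-out, and whether the trifluoromethyl group that remains in compound 4 could itself give way to hydrogen. Among these compounds, they also leave open whether the chloro step holds with the hydroxy group of compound 1 in place of the methoxy group, and, as every value comes from one concentration, they give no potency for any member of the series.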